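The source may report more compounds than this note shows. Statements on the series, on what has been measured and on what is new or still open speak of the compounds shown alone.

Measured compounds:
compound 1 `Cc1ccc(Nc2ncc3c(n2)N(C)C(=O)N(c2cc(NC(=O)c4cccc(C(F)(F)F)c4)ccc2C)C3)cc1` with 18 nM
compound 2 `CNc1cc(Nc2ncc3c(n2)N(C)C(=O)N(c2cc(NC(=O)c4cccc(C(F)(F)F)c4)ccc2C)C3)ccc1C` with 19 nM

Of the compounds shown here, two have been measured in a functional assay on K562 cells (Homo sapiens) for antiproliferative activity, read by CellTiter-Glo and CCK-8 assay, with a stated time of 72 h; a higher number here means a weaker inhibitor of growth, a lower number a stronger inhibitor of growth. Compound 1 gives 18 nM, and compound 2 gives 19 nM. Compound 2 holds the higher of the two numbers, but its nearest neighbour is compound 1 and the step of a 1.1-fold higher number from compound 1 to compound 2 (0.02 log units; within the scatter) lies within the scatter; the two values are indistinguishable on this evidence.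

Compound 3 `Cc1ccc(Nc2ncc3c(n2)N(C)C(=O)N(c2cc(NC(=O)c4cccc(C(F)(F)F)c4)ccc2C)C3)cc1N(C)C` has not been measured. The change from compound 2 is methyl in place of hydrogen on a nitrogen on an aromatic ring, read one bond further out as methylamino to dimethylamino. Going by the values given here, the only measured step that bears on this position is a 1.1-fold higher number from compound 1 to compound 2 (0.02 log units; within the scatter), where adding methylamino in place of hydrogen on the aromatic carbon left the number essentially unchanged. The present step adds a single carbon on that same nitrogen, and nothing in the two measured values points toward a shift in either direction. The expectation is therefore no step beyond the scatter, a 1.1-fold higher number from compound 2 to compound 3 (0.02 log units; within the scatter). Compound 3 is expected to give about 20 nM in this assay, with a range of 9 nM to 45 nM.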

Compound 3, concentration for 50% growth inhibition: 28 nM
For compound 3 the middle estimate is 1.4-fold (0.15 log units) below the measured one; measured number inside the range.
By their numbers in this assay, from the lowest: compounds 1, 2 and 3 (each within the scatter of the next).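

Working from this assay, the hydrogen on the nitrogen of the methylamino group can be replaced by methyl with only a 1.5-fold higher number from compound 2 to compound 3 (0.17 log units; within the scatter), so this position now accommodates dimethylamino as well as methylamino without a step beyond the scatter. Read against hydrogen on the same aromatic carbon, dimethylamino gives a 1.6-fold higher number from compound 1 to compound 3 (0.19 log units; within the scatter), so neither amine separates from the unsubstituted compound 1 on this read-out, and the hydrogen on that nitrogen in compound 2 is shown to be dispensable here. No measurement on these compounds offers an explanation for the size of either step.

The compounds shown span only hydrogen, methylamino and dimethylamino at this aromatic carbon, so it remains open whether a longer chain on the nitrogen, such as ethyl or propyl, or a ring amine such as morpholine or piperazine, would also stay within the scatter. Also open, from the compounds shown here alone, is whether a group of a different kind on that carbon, such as an amide or a carboxylic acid, would produce a step that can be told from the scatter in this assay.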